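One Methyl Group, Two Cores, One Large Step

This account rests on a few compounds, and the source may have more. Where it says the series, first, only, none or still open, it means among the compounds named here.

Compound 1 `COc1cc(CC(O)(COCc2ccccc2)COCc2ccccc2)nc(OC)n1`: > 100000 nM, a limit.
Compound 2 `COc1nc(CC(O)(COCc2ccccc2)COCc2ccccc2)c(C)c(OC)n1`: 6100 nM.
Compound 3 `C[Si](C)(C)CCOCn1c(CC(O)COCc2ccccc2)cc(=O)[nH]c1=O`: > 100000 nM, a limit.

In a functional assay on MIA PaCa-2 cells (Homo sapiens) for antiproliferative activity, read by MTT assay, with a stated time of 72 h (on this read-out lower numbers stand for stronger inhibition and higher numbers for weaker inhibition), compound 1 reaches only a limit. Compound 2 gives 6100 nM, so the step of an at least 16-fold lower number from compound 1 to compound 2 (1.21 log units; beyond the scatter) comes from methyl in place of hydrogen on an aromatic carbon. Compound 3 also stops at a limit. The difference between the cores of compound 1 and compound 3 is not broken down here. Compound 4 `Cc1c(CC(O)COCc2ccccc2)n(COCC[Si](C)(C)C)c(=O)[nH]c1=O` differs from compound 3 by methyl in place of hydrogen on an aromatic carbon. It is the same kind of change as in compound 2, but the place differs: there the carbon was ortho to a methoxy group (2 heavy atoms) and para to a methoxy group (2 heavy atoms); here it is ortho to a group of 1 heavy atom, meta to a group of 8 heavy atoms and para to a group of 1 heavy atom. As far as these compounds go, because compound 3 sits at the limit of > 100000 nM in this assay, at which 2 of the 3 values shown sit, its true value is unknown, so the step to compound 4 may be smaller than it looks. Still, resting on an at least 16-fold lower number from compound 1 to compound 2 (1.21 log units; beyond the scatter), a step of about an at least 5.0-fold lower number from compound 3 to compound 4 (0.69 log units; beyond the scatter) is expected. Compound 4 is estimated at 20000 nM, between 5000 nM and 100000 nM.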

Compound 4, half-maximal inhibitory concentration: > 100000 nM
Compound 4: a limit, no number; the forecaster's own chance of this, stated with the estimate: 40%; middle value at least 5.0-fold (0.69 log units) from the limit.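

Among the compounds shown here, compound 4 stops at a limit, > 100000 nM, as compound 3 does, so no step between compound 3 and compound 4 can be read. What methyl does on the core of compound 3 stays open, and the values shown crowd at one ceiling: the limit of > 100000 nM in this assay, at which 3 of the 4 values shown sit.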